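The source may report more compounds than this note shows. Statements on the series, on what has been measured and on what is new or still open speak of the compounds shown alone.

In a functional assay on MCF7 cells (Homo sapiens) for inhibition, read by MTT assay, with a stated time of 48 h (on this read-out lower numbers stand for stronger inhibition and higher numbers for weaker inhibition), compound 1 `O=C1N/C(=N\Cc2ccccc2)S/C1=C1/CCNC(=O)c2[nH]ccc21` gives 31100 nM. Compound 2 `O=C1N/C(=N\Cc2ccc(C(F)(F)F)cc2)S/C1=C1/CCNC(=O)c2[nH]ccc21` gives > 100000 nM, which is a limit of the assay and not a number. Compound 3 `O=C1N/C(=N\Cc2ccc(Cl)cc2)S/C1=C1/CCNC(=O)c2[nH]ccc21` gives > 100000 nM, also a limit. Compound 4 `O=C1N/C(=N\Cc2ccccc2Cl)S/C1=C1/CCNC(=O)c2[nH]ccc21` differs from compound 3 by one change 2-chlorophenyl in place of 4-chlorophenyl on a saturated chain carbon bound to a double-bonded nitrogen. Among the compounds with values here, two measured steps bear on this. Placing chloro on the aromatic ring gave an at least 3.2-fold higher number from compound 1 to compound 3 (0.50 log units; beyond the scatter), and placing trifluoromethyl there gave an at least 3.2-fold higher number from compound 1 to compound 2 (0.50 log units; beyond the scatter). Compound 4 keeps a chloro on that ring, so no step beyond the scatter is expected, and the expected step is an at least 1.4-fold lower number from compound 3 to compound 4 (0.15 log units; that floor lies within the scatter). For compound 4 the estimated value is 70000 nM, with an expected range of 25000 nM to 150000 nM.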

Compound 4, half-maximal inhibitory concentration: 21200 nM
The estimate for compound 4 lay 3.3-fold (0.52 log units) above the measured number; measured number below the stated range.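

Exchanging 4-chlorophenyl for 2-chlorophenyl, with the same atoms joined differently, gives an at least 4.7-fold lower number from compound 3 to compound 4 (0.67 log units; beyond the scatter), so where the chloro sits matters and not only whether one is present. Set against the unsubstituted ring, the same compound shows a 1.5-fold lower number from compound 1 to compound 4 (0.17 log units; within the scatter), so a chloro on this ring need not push the number up as it did in compound 3. Compound 3 carries a limit and not a number, so the first step is only a floor: the limit of > 100000 nM in this assay, at which 2 of the 4 values shown sit.

Going by these compounds, whether an amine or a methoxy group in place of the chloro of 2-chlorophenyl would read like compound 4 stays open.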